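Expected Activity of a Dichlorophenylurea Analogue in Cells

A few compounds are considered here, and "the series" means these few. Any claim that something is new, unique, unknown or untested is made for them only; others in the source may bear on it.

Compound 1 `COc1cc2cc(Oc3ccc(NC(=O)Nc4ccccc4)cc3)c(C)nc2cc1OC` is the parent of this small set. In a functional assay on SNB-19 cells (Homo sapiens) for inhibition, read by sulforhodamine B assay, with a stated time of 48 h, tested at 10 uM (a lower number here means a stronger effect, a higher number a weaker effect of the compound at the concentration tested), compound 1 gives 94.8%, the second highest of the three numbers. Compound 2 `COc1cc2cc(Oc3ccc(NC(=O)Nc4ccc(C)cc4)cc3)c(C)nc2cc1OC` gives 97.1%, and the step of a number 2.3 percentage points higher from compound 1 to compound 2 (within the scatter) shows that the two stand at the same level. Compound 3 `COc1cc2cc(Oc3ccc(NC(=O)Nc4ccc(Cl)c(C(F)(F)F)c4)cc3)c(C)nc2cc1OC` gives 23.7%; the steps of a number 71.1 percentage points lower from compound 1 to compound 3 (beyond the scatter) and a number 73.4 percentage points lower from compound 2 to compound 3 (beyond the scatter) are both large and well beyond the scatter.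

Compound 4 `COc1cc2cc(Oc3ccc(NC(=O)Nc4ccc(Cl)c(Cl)c4)cc3)c(C)nc2cc1OC` has not yet been measured in this assay. Its difference from compound 1 is 3,4-dichlorophenyl in place of phenyl on an amide-type nitrogen. Among the compounds with values here, the step that bears most on this change is the one from compound 1 to compound 3, where a 4-chloro-3-(trifluoromethyl)phenyl group entered at the same amide-type nitrogen and the number fell by a number 71.1 percentage points lower from compound 1 to compound 3 (beyond the scatter). The change to compound 4 shares the chlorine at the fourth position of that ring but replaces the trifluoromethyl with a second chlorine, so a drop of comparable direction, though of uncertain size, is expected. Compound 4 is therefore estimated to give 40% in this assay, with a range from 15% to 80%, an expected step of a number 54.8 percentage points lower from compound 1 to compound 4 (beyond the scatter).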

Compound 4, a percentage reported as activity, at one concentration (the size of the read-out at that concentration, not a potency): 28.7%
Beside the measured number, compound 4's estimate is 11.3 percentage points above it; the measured number falls inside the stated range.
By their numbers in this assay, from the lowest: compounds 3 and 4 (each within the scatter of the next); then compounds 1 and 2 (each within the scatter of the next).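

In this assay, 3,4-dichlorophenyl on the amide-type nitrogen gives a number 66.1 percentage points lower from compound 1 to compound 4 (beyond the scatter) and a number 68.4 percentage points lower from compound 2 to compound 4 (beyond the scatter), so the large fall seen with compound 3 does not require a trifluoromethyl group. Chloro in place of trifluoromethyl on an aromatic carbon gives a number 5 percentage points higher from compound 3 to compound 4 (within the scatter), so compound 3 and compound 4 cannot be told apart in this read-out, and the two groups are interchangeable here as far as these compounds show. No measurement at hand accounts for the gap that separates these two substituted rings from the phenyl and 4-methylphenyl rings.

From the compounds shown here alone, it remains open whether a single chloro group on this ring would be enough for the fall, or whether both substituents are needed. Going by these compounds, it is also open whether a methoxy group, an amine or a carboxylic acid on the same ring would keep the number as low as the two halogen-bearing rings do, or return it to the level of compound 1.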